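The compounds below may be only part of what the source reports. "The series", "measured", "known", "first", "only" and "open" are said of these compounds alone.

Of the compounds shown here, three sharing one core have been tested in a functional assay (aorta) with Rattus norvegicus as the target; on this read-out higher numbers stand for higher potency (the scale is a negative logarithm) and lower numbers for lower potency. Compound 1 `COc1ccc2c(c1)C(n1ccccc1=O)=CC(C)(C)O2` gives 6.55. Compound 2 `CC1(C)C=C(n2ccccc2=O)c2cc(C(=O)c3ccccc3)ccc2O1`, which carries a benzoyl in place of the methoxy on an aromatic carbon, gives 6.61. Compound 3 `CC1(C)C=C(n2ccccc2=O)c2cc(C(=O)c3cccs3)ccc2O1`, with a (thiophen-2-yl)carbonyl at that same place, gives 6.4. Compound 3 holds the lowest of the three numbers, yet all three sit close together: the step of a number 0.15 log units lower from compound 1 to compound 3 (within the scatter) and the step of a number 0.21 log units lower from compound 2 to compound 3 (within the scatter) both fall within the scatter, as does a number 0.06 log units higher from compound 1 to compound 2 (within the scatter). Swapping the group on that aromatic carbon between methoxy, benzoyl and (thiophen-2-yl)carbonyl has not moved the read-out beyond the scatter.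

Compound 4 `CC1(C)C=C(n2ccccc2=O)c2cc(C(=O)c3ccco3)ccc2O1` differs from compound 3 in one place: furan-2-yl in place of thiophen-2-yl on a carbonyl carbon. The measured step that bears most directly on this is a number 0.21 log units lower from compound 2 to compound 3 (within the scatter), where one aromatic ring on the carbonyl carbon replaced another and nothing beyond the scatter followed; the steps of a number 0.06 log units higher from compound 1 to compound 2 (within the scatter) and a number 0.15 log units lower from compound 1 to compound 3 (within the scatter) point the same way. Exchanging thiophen-2-yl for furan-2-yl is a change of the same kind, so no shift beyond the scatter is expected. The step expected is a number 0.05 log units higher from compound 3 to compound 4 (within the scatter). Compound 4 is estimated at 6.45, most likely between 6.1 and 6.8.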

Compound 4, logarithm of the reciprocal of the active concentration, log(1/C): 6.49
Compound 4: middle estimate off by 0.04 log units, on the low side; the range from low to high includes it.
By their numbers in this assay, from the lowest: compounds 3, 4, 1 and 2 (each within the scatter of the next).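

With compound 4, a third aromatic ring now stands on the carbonyl carbon, and in this assay the read-out stays put, with a number 0.09 log units higher from compound 3 to compound 4 (within the scatter) and a number 0.12 log units lower from compound 2 to compound 4 (within the scatter). Going by these compounds alone, the first of these steps adds something the earlier compounds could not show: with the five-membered aromatic ring kept, exchanging its sulfur for oxygen also leaves the number within the scatter, as did the change from phenyl to thiophen-2-yl. On the aromatic carbon, (furan-2-yl)carbonyl now joins benzoyl and (thiophen-2-yl)carbonyl as a replacement for methoxy that causes no shift beyond the scatter, with a number 0.06 log units lower from compound 1 to compound 4 (within the scatter). Nothing available here explains why these exchanges leave the read-out in place.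

From the compounds shown here alone, every group on the carbonyl carbon so far is a phenyl or a five-membered aromatic ring, so it remains open whether a pyridine ring or a short alkyl chain there would hold the read-out equally well. Going by these compounds, on the aromatic carbon, it is equally open whether an amine or a carboxylic acid in place of these groups would move the number beyond the scatter.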